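From 3,3-dimethylbutyl to sec-butyl on the shared core

This account rests on a few compounds, and the source may have more. Where it says the series, first, only, none or still open, it means among the compounds named here.

Measured in a functional assay on K562 cells (Homo sapiens) for antiproliferative activity, read by CellTiter-Glo, with a stated time of 72 h; a lower number here means that less compound is needed, a higher number that more compound is needed for the effect:
Compound 1 `CCCCCNc1ncnc2c1ncn2[C@@H]1O[C@H](COS(N)(=O)=O)[C@@H](O)[C@H]1O`: 181 nM
Compound 2 `CCCCCCCNc1ncnc2c1ncn2[C@@H]1O[C@H](COS(N)(=O)=O)[C@@H](O)[C@H]1O`: 132 nM
Compound 3 `CC(C)(C)CCNc1ncnc2c1ncn2[C@@H]1O[C@H](COS(N)(=O)=O)[C@@H](O)[C@H]1O`: 929 nM

Of these three, compound 3 carries the highest number, 929 nM, and its gaps to the other two lie beyond the scatter. Compound 4 `CCC(C)Nc1ncnc2c1ncn2[C@@H]1O[C@H](COS(N)(=O)=O)[C@@H](O)[C@H]1O` has not yet been measured. Its difference from compound 3 is sec-butyl in place of 3,3-dimethylbutyl on a nitrogen on an aromatic ring.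

For the measured compounds named here, two measured steps bear most directly on this change. They are a 5.1-fold higher number from compound 1 to compound 3 (0.71 log units; beyond the scatter) and a 7.0-fold higher number from compound 2 to compound 3 (0.85 log units; beyond the scatter), and each places tert-butyl on the chain in place of a straight group. The remaining step, a 1.4-fold lower number from compound 1 to compound 2 (0.14 log units; within the scatter), lies within the scatter and shows no dependence on length between those two compounds. Going by the values given here, compound 4 loses the tert-butyl end, but no measured compound carries sec-butyl, so the data offer no direct comparison. A partial return toward the lower numbers therefore seems the likeliest outcome in this assay, though less than the full distance. The expected change is a 2.3-fold lower number from compound 3 to compound 4 (0.37 log units; beyond the scatter). For compound 4, the estimated value is 400 nM, with an expected range of 120 nM to 1300 nM.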

Compound 4, half-maximal effective concentration: > 1000 nM
Compound 4 gave a limit, no number; the forecaster's own chance of this, stated with the estimate: 5%; middle value at least 2.5-fold (0.39 log units) from the limit.
By their numbers in this assay, from the lowest: compounds 2 and 1 (each within the scatter of the next); then compound 3. At a limit, above all of these: compound 4.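

In this assay, compound 4 is read only as a limit and not as a number: the limit of > 1000 nM in this assay, at which 1 of the 4 values shown sits. For the compounds shown here, the straight chains still stand clearly apart from sec-butyl on this nitrogen on an aromatic ring, with an at least 7.5-fold higher number from compound 2 to compound 4 (0.87 log units; beyond the scatter) and an at least 5.5-fold higher number from compound 1 to compound 4 (0.74 log units; beyond the scatter), so among the four compounds both branched groups give higher numbers than both straight ones, and no compound goes against this. The third step, an at least 1.0-fold higher number from compound 3 to compound 4 (0.03 log units; that floor lies within the scatter), has a floor within the scatter, so it does not order sec-butyl and 3,3-dimethylbutyl, but it also gives no sign of the partial return toward the lower numbers that removing the tert-butyl end might have brought.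

As far as these compounds go, the actual number for compound 4 remains open, and so does the question of whether the branch itself or the smaller size of sec-butyl matters more, as sec-butyl differs from pentyl and heptyl in both respects. A straight butyl chain on the same nitrogen would separate those two, while a cyclopentyl ring there would show how a closed carbon group compares with the open branched ones.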